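The source may hold more compounds than are shown below. What is called first, only, known or untested is meant among the compounds shown, and "the series" means these compounds.

Three compounds share one core and differ only in the aryl group on the saturated chain carbon bound to an aromatic nitrogen. Compound 1, `O=c1ccoc2cc(OCc3cn(Cc4ccc([N+](=O)[O-])cc4)nn3)ccc12`, gives 19300 nM in a functional assay on SW480 cells (Homo sapiens) for cytotoxicity, read by MTT assay, with a stated time of 48 h; on this read-out higher numbers stand for weaker inhibition and lower numbers for stronger inhibition. Compound 3, `COc1ccc(Cn2cc(COc3ccc4c(=O)ccoc4c3)nn2)cc1`, gives 20400 nM in this assay. Compound 2, `O=c1ccoc2cc(OCc3cn(Cc4ccc(Cl)cc4Cl)nn3)ccc12`, reaches only a limit, > 100000 nM, in this assay, the limit at which one of the three values sits (the limit of > 100000 nM in this assay, at which 1 of the 3 values shown sits). Compound 3 stands alongside compound 1, the step of a 1.1-fold higher number from compound 1 to compound 3 (0.02 log units; within the scatter) lying within the scatter. The exchanges of the aryl group that reach beyond the scatter are an at least 5.1-fold higher number from compound 1 to compound 2 (0.71 log units; beyond the scatter) and an at least 4.9-fold lower number from compound 2 to compound 3 (0.69 log units; beyond the scatter), both involving the limit of compound 2.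

Compound 4, `N#Cc1cccc(Cn2cc(COc3ccc4c(=O)ccoc4c3)nn2)c1`, carries 3-cyanophenyl in place of 4-methoxyphenyl on a saturated chain carbon bound to an aromatic nitrogen. Among the compounds with values here, two measured steps bear on this change: a 1.1-fold higher number from compound 1 to compound 3 (0.02 log units; within the scatter) stayed within the scatter, whereas an at least 4.9-fold lower number from compound 2 to compound 3 (0.69 log units; beyond the scatter) went beyond it. The change from compound 3 to compound 4 keeps a single substituent on the phenyl ring, as in compound 1 and compound 3, and no step beyond the scatter is expected in this assay. Compound 4 is therefore estimated at 22000 nM, between 8000 nM and 70000 nM. That estimate amounts to a step of a 1.1-fold higher number from compound 3 to compound 4 (0.03 log units; within the scatter).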

Compound 4, half-maximal inhibitory concentration: > 100000 nM
Compound 4: only a limit was reported; the forecaster's own chance of this, stated with the estimate: 15%; middle value at least 4.5-fold (0.65 log units) from the limit.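

The value of compound 4 is a limit and not a number, and it is the same limit that compound 2 reached: the limit of > 100000 nM in this assay, at which 2 of the 4 values shown sit. A single substituent on the phenyl ring is therefore not enough to hold the read-out in this assay, where compound 1 and compound 3 lay within the scatter of each other, yet 3-cyanophenyl gives an at least 4.9-fold higher number from compound 3 to compound 4 (0.69 log units; beyond the scatter) and an at least 5.1-fold higher number from compound 1 to compound 4 (0.71 log units; beyond the scatter). The step from compound 2 to compound 4 cannot be read, both values being limits.

On these data alone, what a 4-cyanophenyl group would give at this place stays open, so the nitrile and its place on the ring cannot be told apart. The compounds shown also leave open how an amine or a carboxylic acid on the phenyl ring would read in this assay.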